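Working notes on compounds 1 to 3

This account rests on a few compounds, and the source may have more. Where it says the series, first, only, none or still open, it means among the compounds named here.

Measured so far:
compound 1 `O=C(CCCc1ncc(C(F)(F)F)cc1Cl)N1CCc2c(Cl)c(O)c(O)c(Cl)c2C1` gives 61% in a functional assay (Homo sapiens), tested at 1 uM; a lower number here means a stronger effect, a higher number a weaker effect of the compound at the concentration tested
compound 2 `O=C(CCCc1ncc(C(F)(F)F)cc1C1CCCCC1)N1CCc2c(Cl)c(O)c(O)c(Cl)c2C1` gives "not determined" (no result reported) in this assay

In this assay compound 1 gives 61%. Compound 2 is reported as "not determined" (no result reported) in this assay and so has no single number there; it stands nowhere on the numbers shown. Compound 3 `O=C(CCCc1ncc(C(F)(F)F)cc1-c1ccccc1)N1CCc2c(Cl)c(O)c(O)c(Cl)c2C1` differs from compound 2 by phenyl in place of cyclohexyl on an aromatic carbon. No step between measured compounds is shown, and without a value for compound 2 neither size nor direction of the change to compound 3 can be read from the data; the only anchor is compound 1 with 61%. Compound 3 is therefore expected to give about 60% in this assay, estimated within 25% to 95%.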

Compound 3, a percentage reported as activity, at one concentration (the size of the read-out at that concentration, not a potency): 90%
Estimate against measurement, compound 3: 30 percentage points below; the measured number falls inside the stated range.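

Phenyl in place of chloro on this aromatic carbon gives a number 29 percentage points higher from compound 1 to compound 3 (beyond the scatter) in this assay, so the effect at the concentration tested is weaker with phenyl than with chloro. This position therefore responds to the group it carries. Compound 2 has no number, so the step from cyclohexyl to phenyl cannot be read. Nothing measured here accounts for the rise.

On these data alone, how a methyl group, a methoxy group or an amine on this carbon would read remains open. As far as these compounds go, it is equally open whether any group here gives a number below that of compound 1.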